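The source may hold more compounds than are shown below. What is called first, only, known or untested is meant among the compounds shown, and "the series" means these compounds.

Among the measured compounds shown here, compound 1 `O=c1oc2ncccc2n1CCN1CCN(c2ccc(F)cc2)CC1` has the highest number of the two compounds measured so far. In a functional assay on the whole organism for inhibition, with Mus musculus as the target, in the writhing test, at a dose of 50 mg/kg by the oral route (a higher number here means more inhibition at the dose given (going by the name of the read-out), a lower number less inhibition), compound 1 gives 83%, while compound 2 `O=c1oc2ncccc2n1CCN1CCN(c2cccc3ccccc23)CC1` gives 33% in this assay, a gap that lies beyond the usual scatter of such measurements, so the inhibition in this assay is higher for compound 1 than for compound 2. Compound 3 `COc1ccccc1N1CCN(CCn2c(=O)oc3ncccc32)CC1` has not been measured. It differs from compound 1 in one place: 2-methoxyphenyl in place of 4-fluorophenyl on an amine nitrogen in a ring. For the measured compounds named here, nothing measured so far shows how this particular change affects the read-out, since compound 2 carries a different aromatic group. Because compound 1 gives 83%, a step of moderate size downward is expected in this assay, amounting to a number 18 percentage points lower from compound 1 to compound 3 (beyond the scatter). Compound 3 is therefore estimated to give 65%, within a range from 35% to 90%.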

Compound 3, a percentage reported as inhibition, in the whole organism at one dose (the size of the read-out at that dose, not a potency): 52%
The estimate for compound 3 lay 13 percentage points above the measured number; measured number inside the range.
By their numbers in this assay, from the lowest: compound 2; then compound 3; then compound 1.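

Putting 2-methoxyphenyl in place of 4-fluorophenyl on the amine nitrogen in the ring gives a number 31 percentage points lower from compound 1 to compound 3 (beyond the scatter) in this assay, a large step. Among the compounds shown here, this is the first direct reading of this change, and it shows that the read-out at this position depends on the group carried by the phenyl ring: both groups keep one six-membered aromatic ring of carbon only, yet the number differs clearly. Nothing measured here explains this step through any property of the two groups.

The compounds shown leave open whether the step follows from the kind of group on the phenyl ring or from where it sits. A 4-methoxyphenyl or a 2-fluorophenyl on the same nitrogen would separate these two readings.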